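Phenyl for Benzyl on Sulfur: Extending a Growth Assay

A few compounds are considered here, and "the series" means these few. Any claim that something is new, unique, unknown or untested is made for them only; others in the source may bear on it.

Measured compounds:
Compound 1 `Cc1ccc(S(=O)(=O)/C(=C/c2ccc(C)s2)C(=O)c2ccc(Cl)cc2)cc1` gives 50000 nM in a functional assay on DU-145 cells (Homo sapiens) for inhibition, read by trypan blue exclusion, with a stated time of 96 h; on this read-out higher numbers stand for weaker inhibition of growth and lower numbers for stronger inhibition of growth.
Compound 2 `Cc1ccc(CS(=O)(=O)/C(=C/c2ccc(C)s2)C(=O)c2ccc(Cl)cc2)cc1` gives 25000 nM in this assay.
Compound 3 `Cc1ccc(CS/C(=C/c2ccc(Cl)cc2)C(=O)c2ccc(Cl)cc2)cc1` gives 10000 nM in this assay.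

Compound 4 `Cc1ccc(S/C(=C/c2ccc(Cl)cc2)C(=O)c2ccc(Cl)cc2)cc1` has not yet been measured. It differs from compound 3 by 4-methylphenyl in place of 4-methylbenzyl on a sulfur. A change of the same kind, (4-methylphenyl in place of 4-methylbenzyl on a sulfonyl sulfur), links compound 2 to compound 1, where the step was a 2.0-fold higher number from compound 2 to compound 1 (0.30 log units; within the scatter). The places are not identical: in compound 1 and compound 2 the change sits on a sulfonyl sulfur whose other neighbours are a double-bonded chain carbon, whereas in compound 3 and compound 4 it sits on a sulfur whose other neighbours are a double-bonded chain carbon, so this is the same kind of change, not the same change. The difference between the cores of compound 2 and compound 3 is not broken down here.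

From compound 3, the expected step is a 1.7-fold higher number from compound 3 to compound 4 (0.23 log units; within the scatter), resting on the earlier step of a 2.0-fold higher number from compound 2 to compound 1 (0.30 log units; within the scatter). Compound 4 is therefore estimated at 17000 nM in this assay, between 7000 nM and 45000 nM.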

Compound 4, concentration for 50% growth inhibition: 10000 nM
For compound 4 the middle estimate is 1.7-fold (0.23 log units) above the measured one, within the range that was stated.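

In this assay putting 4-methylphenyl in place of 4-methylbenzyl on a sulfur gives no change at the digits printed from compound 3 to compound 4 (within the scatter) and so adds a second example of this swap. Set side by side, the two examples read: the same change on two cores in this assay, a 2.0-fold higher number (0.30 log units; within the scatter) from compound 2 to compound 1 and no change at the digits printed (within the scatter) from compound 3 to compound 4, 2.0-fold (0.30 log units) apart, within the scatter of two such steps. The swap therefore looks the same on both cores as far as these numbers can tell, but neither step stands clear of the scatter, so this shows only that no effect of the swap was detected on either core, not that it would stay without effect on a further core.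

The compounds shown leave open what other groups on the sulfur would do, such as a longer chain, an amine or a carboxylic acid. They also leave open whether any such group would shift the number beyond the scatter.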